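A few compounds are considered here, and "the series" means these few. Any claim that something is new, unique, unknown or untested is made for them only; others in the source may bear on it.

Measured compounds in the series:

compound 1, `Cc1c(Cl)cccc1CCCCOc1ccc(C#Cc2ccc(F)c3c(CCCC(=O)O)c(C)n(CCCC(=O)O)c23)cc1`, 12 nM
compound 2, `Cc1c(CCCC(=O)O)c2cccc(/C=C/c3ccc(OCCCCc4c(F)c(F)cc(F)c4F)cc3)c2n1CC(=O)O`, 3.7 nM
compound 3, `Cc1c(Cl)cccc1CCCCOc1ccc(C#Cc2cccc3c(CCC(=O)O)c(C)n(CCCCC(=O)O)c23)cc1`, 60 nM

All three were run in a functional assay on HEK293 cells for antagonist activity at cysteinyl leukotriene receptor 2 (Homo sapiens), read by fluorescence and calcium flux, with stated times of 30 min and 1 h; a lower number here means a stronger inhibitor, a higher number a weaker inhibitor. Compound 2 stands lowest of the three numbers: against compound 1 the gap is beyond the scatter, and against compound 3 it is wider still, so on the numbers shown compound 2 is the strongest inhibitor of the set. Compound 3 is the weakest, with compound 1 between the two.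

The next compound, compound 4, `Cc1c(F)cccc1CCCCOc1ccc(/C=C/c2cccc3c(CCCC(=O)O)c(C)n(CC(=O)O)c23)cc1`, keeps the shared core of compound 2 with both acid chains and the linker unchanged. The one difference lies at the far end of the chain that leaves the aromatic oxygen:

3-fluoro-2-methylphenyl in place of 2,3,5,6-tetrafluorophenyl on a saturated chain carbon, four bonds along the chain from an oxygen on an aromatic ring

Within the data shown here, no measured pair in the set isolates this change, so its size cannot be read from the data; the two-step difference between compound 2 and compound 1 mixes it with other changes and gives no clean guide. Given that the core and chains of compound 2 are kept, compound 4 is expected to stay in the same region, with a modest weakening at most, and the step from compound 2 to compound 4 is estimated at a 1.6-fold higher number from compound 2 to compound 4 (0.21 log units; within the scatter). Compound 4 is accordingly expected to give about 6 nM in this assay, within a range of 2 nM to 18 nM.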

Compound 4, half-maximal inhibitory concentration: 7.2 nM
The estimate for compound 4 lay 1.2-fold (0.08 log units) below the measured number, within the range that was stated.
By their numbers in this assay, from the lowest: compounds 2, 4 and 1 (each within the scatter of the next, the first and the last beyond it); then compound 3.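

In this assay, among these compounds, the change at this place, on a saturated chain carbon, four bonds along the chain from an oxygen on an aromatic ring, can now be read on its own for the first time: 3-fluoro-2-methylphenyl in place of 2,3,5,6-tetrafluorophenyl gives a 1.9-fold higher number from compound 2 to compound 4 (0.29 log units; within the scatter) with the shared core, both acid chains and the linker held the same. The two groups therefore cannot be told apart by this read-out, although they differ in make-up, at 10 heavy atoms (6 carbon, 4 fluorine) against 8 heavy atoms (7 carbon, 1 fluorine), so at this position the series does not depend on keeping the 2,3,5,6-tetrafluorophenyl group. Nothing available explains why the two groups read alike.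

Going by these compounds, whether this position also accepts a phenyl ring carrying an amine or a carboxylic acid, or a pyridine ring in place of the phenyl, remains open. Also open, on these data alone, are a longer chain in front of either ring and whether the same exchange reads alike on a compound with the alkyne linker of compound 1.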